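Swapping the Sulfonamide Aryl Group on Compound 3

A few compounds are considered here, and "the series" means these few. Any claim that something is new, unique, unknown or untested is made for them only; others in the source may bear on it.

Measured so far in a functional assay on MCF7 cells (Homo sapiens) for inhibition, read by CCK-8 assay, with a stated time of 72 h; a lower number here means a stronger inhibitor, a higher number a weaker inhibitor:
- compound 1 `O=C(/C=C/c1cccnc1)NCCCCCc1cccc(S(=O)(=O)Nc2ccccc2)c1` gives 12.5 nM
- compound 2 `O=C(/C=C/c1cccnc1)NCCCCCCCc1cccc(S(=O)(=O)Nc2ccccc2)c1` gives 42.6 nM
- compound 3 `Cc1cccc(NS(=O)(=O)c2cccc(CCCCCCNC(=O)/C=C/c3cccnc3)c2)c1` gives 4 nM

Compound 3 has the lowest number of the three, which makes it the strongest inhibitor measured so far. Compound 1 comes nearest to it and compound 2 lies furthest away, both beyond the usual scatter. No two of these compounds differ in one place only, so no measured step isolates a single change.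

The next compound is compound 4 `O=C(/C=C/c1cccnc1)NCCCCCCc1cccc(S(=O)(=O)Nc2ccc(F)cc2)c1`, which has 4-fluorophenyl in place of 3-methylphenyl on a sulfonamide nitrogen. The counted difference is 4-fluorophenyl in place of 3-methylphenyl on a sulfonamide nitrogen and the rest of compound 3 stays as it is.

Compound 1 carries neither the methyl nor the fluorine and still reads 12.5 nM, so a swap of this group is not expected to cost much. That evidence is weak, since the chain of compound 1 differs too and the data cannot separate the two changes. A small rise in the number is expected, estimated as a 1.8-fold higher number from compound 3 to compound 4 (0.24 log units; within the scatter), and it would probably stay within the scatter. For compound 4 the expected value is 7 nM, with an estimated range from 2 nM to 25 nM.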

Compound 4, half-maximal inhibitory concentration: 0.91 nM
Beside the measured number, compound 4's estimate is 7.7-fold (0.89 log units) above it; the measured number lies below the stated range.
By their numbers in this assay, from the lowest: compound 4; then compound 3; then compound 1; then compound 2.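

In this assay, among the compounds shown here, replacing 3-methylphenyl with 4-fluorophenyl on the sulfonamide nitrogen gives a 4.4-fold lower number from compound 3 to compound 4 (0.64 log units; beyond the scatter), and this is the only comparison in the set where a single place changes. It shows that the group on this nitrogen matters in its own right, since the step lies beyond the usual scatter, even though the leaving and entering groups match in heavy-atom count, with one six-membered aromatic ring each, no hydrogen-bond donors or acceptors, and no net charge. No measurement shown here speaks to why the number falls with this swap.

From the compounds shown here alone, the step removes the methyl and adds the fluorine together, so it remains open whether the lower number follows the fluorine, the loss of the methyl, or both, and how 3-fluorophenyl, 4-methylphenyl or 4-chlorophenyl would read on the same nitrogen. Going by these compounds, it is also open whether 4-fluorophenyl would keep its effect on the shorter chain of compound 1 or the longer chain of compound 2, or how a ring carrying an amine or a carboxylic acid would read at this place.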